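Aryl exchange on the thiophene carbon: pyridin-3-yl analogue

The source may hold more compounds than are shown below. What is called first, only, known or untested is meant among the compounds shown, and "the series" means these compounds.

Measured in an assay on membranes from brain for displacement of a labelled ligand from Sigma non-opioid intracellular receptor 1 (Cavia porcellus), read by scintillation counting, with a stated time of 120 min; on this read-out higher numbers stand for weaker inhibition and lower numbers for stronger inhibition:
Compound 1 `COc1ccc(-c2cc3c(s2)C2(CCN(Cc4ccccc4)CC2)OC(OC)C3)cc1` gives 56 nM.
Compound 2 `COC1Cc2cc(-c3ccc(C#N)cc3)sc2C2(CCN(Cc3ccccc3)CC2)O1` gives 20 nM.
Compound 3 `COC1Cc2cc(-c3cccc4ccccc34)sc2C2(CCN(Cc3ccccc3)CC2)O1` gives 12 nM.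

Compound 3 carries the lowest number of the three; compound 2 sits within the scatter of it, compound 1 lies beyond it, as the step of a 4.7-fold lower number from compound 1 to compound 3 (0.67 log units; beyond the scatter) shows. Compound 4 `COC1Cc2cc(-c3cccnc3)sc2C2(CCN(Cc3ccccc3)CC2)O1` differs from compound 3 by pyridin-3-yl in place of naphthalen-1-yl on an aromatic carbon. Among the measured compounds shown here, the steps that bear on this site are a 4.7-fold lower number from compound 1 to compound 3 (0.67 log units; beyond the scatter) and a 1.7-fold lower number from compound 2 to compound 3 (0.22 log units; within the scatter): the two-ring group gave the lowest number, single-ring groups gave higher ones. Removing the second ring in compound 4 is therefore expected to raise the number in this assay, by an estimated 4.2-fold higher number from compound 3 to compound 4 (0.62 log units; beyond the scatter). The estimate for compound 4 is 50 nM, range 18 nM to 150 nM.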

Compound 4, inhibition constant: 2.5 nM
For compound 4 the middle estimate is 20-fold (1.30 log units) above the measured one, outside the stated range (below it).
By their numbers in this assay, from the lowest: compound 4; then compounds 3 and 2 (each within the scatter of the next); then compound 1.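

At this aromatic carbon next to the ring sulfur, a second aromatic ring is not needed for a low number in this assay: the change to pyridin-3-yl gives a 4.8-fold lower number from compound 3 to compound 4 (0.68 log units; beyond the scatter). The same group also improves on both single-ring aryl groups, with an 8.0-fold lower number from compound 2 to compound 4 (0.90 log units; beyond the scatter) and a 22-fold lower number from compound 1 to compound 4 (1.35 log units; beyond the scatter), so ring count alone does not set the order. No measurement shown explains these steps.

As far as these compounds go, whether the lower number follows the ring nitrogen or its location stays open. Unsubstituted phenyl, pyridin-2-yl and pyridin-4-yl would separate these.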